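The source may report more compounds than this note shows. Statements on the series, on what has been measured and on what is new or still open speak of the compounds shown alone.

Measured compounds:
Compound 1 `COc1ccc(OC)c(-n2nncc2CN2C(=O)C3(C(C#N)=C(N)Oc4c(N)cc5nc6ccccc6nc5c43)c3ccccc32)c1`: in an ADME assay on L02 cells (Homo sapiens) for antiproliferative activity, read by MTT assay, with a stated time of 48 h (a higher number here means a weaker inhibitor, a lower number a stronger inhibitor), compound 1 gives > 50000 nM, a limit of the assay rather than a number.
Compound 2 `Cc1ccc(Cl)cc1-n1nncc1CN1C(=O)C2(C(C#N)=C(N)Oc3c(N)cc4nc5ccccc5nc4c32)c2ccccc21`: in this assay compound 2 gives > 50000 nM, likewise a limit.
Compound 3 `N#CC1=C(N)Oc2c(N)cc3nc4ccccc4nc3c2C12C(=O)N(Cc1cnnn1-c1ccc([N+](=O)[O-])cc1[N+](=O)[O-])c1ccccc12`: in this assay compound 3 gives 22800 nM.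

Going by the values given here, compound 3 thus holds the only number in the set; the other two values are limits, both sitting at the limit of > 50000 nM in this assay, at which 2 of the 3 values shown sit. The two steps leading to it, an at least 2.1-fold lower number from compound 1 to compound 3 (0.34 log units; beyond the scatter) and an at least 2.1-fold lower number from compound 2 to compound 3 (0.34 log units; beyond the scatter), are readable only as at least that size.

Compound 4 `N#CC1=C(N)Oc2c(N)cc3nc4ccccc4nc3c2C12C(=O)N(Cc1cnnn1-c1c(Cl)cc(Cl)cc1Cl)c1ccccc12` differs from compound 3 in one place: 2,4,6-trichlorophenyl in place of 2,4-dinitrophenyl on an aromatic nitrogen. Neither measured step covers the trichlorophenyl group. Among the compounds with values here, both run from a limit toward the dinitrophenyl compound, so they show only that compound 3 is the stronger inhibitor among the three, not how a third aryl group fares. The two limit values for the other aryl groups leave a return toward the limit open. The expected value for compound 4 is 40000 nM, between 12000 nM and 130000 nM. The step of a 1.8-fold higher number from compound 3 to compound 4 (0.24 log units; within the scatter) is expected to be modest, and a limit-only outcome for compound 4 remains plausible.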

Compound 4, half-maximal inhibitory concentration: > 50000 nM
Compound 4 gave a limit, no number (the forecaster's own chance of this, stated with the estimate: 50%); at least 1.2-fold (0.09 log units) between middle value and limit.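

In this assay, replacing 2,4-dinitrophenyl with 2,4,6-trichlorophenyl on the aromatic nitrogen gives an at least 2.1-fold higher number from compound 3 to compound 4 (0.34 log units; beyond the scatter), which can be read only as a minimum size and shows that a third aryl group does not retain the measurable value of compound 3. Among the four aryl groups shown, only 2,4-dinitrophenyl brings the value off the limit, while compound 1, compound 2 and compound 4 all remain at it: the limit of > 50000 nM in this assay, at which 3 of the 4 values shown sit. The steps among compound 1, compound 2 and compound 4 cannot be read, as both ends of each are limits, so these three aryl groups cannot be ranked against one another.

On these data alone, it remains open whether the measurable value of compound 3 needs both nitro groups or would persist with a phenyl group carrying a single nitro group, an aminophenyl group or an unsubstituted phenyl group. As far as these compounds go, the full size of the step to compound 4 also stays open, as does any effect of changes elsewhere on the shared core.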